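The compounds below may be only part of what the source reports. "The series", "measured", "known", "first", "only" and "open" are said of these compounds alone.

Measured compounds:
- compound 1, `O=C(COc1ccc(C(=O)/C=C/c2ccc(Cl)cc2Cl)cc1)N[C@H]1CCOC1=O`: 8610 nM
- compound 2, `Cc1cc(Cl)ccc1NCC(=O)N[C@H]1CCOC1=O`: > 64000 nM

The study measures a functional assay on DU-145 cells (Homo sapiens) for antiproliferative activity, read by MTT assay, with a stated time of 72 h; on this read-out higher numbers stand for weaker inhibition and lower numbers for stronger inhibition. In this assay, going by the values given here, compound 1 gives 8610 nM, which is the only number among the two measured compounds. Compound 2 gives > 64000 nM in this assay, and that is a limit of the assay rather than a number; (the limit of > 64000 nM in this assay, at which 1 of the 2 values shown sits). Among the compounds with values here, compound 1 and compound 2 differ in more than one place, and no single step between them is set out. Within the data shown here, the two values show only that compound 1 lies well inside the measurable range while compound 2 does not.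

The piece follows the step from compound 1 to compound 3, `O=C(COc1ccc(C(=O)/C=C/c2cccc([N+](=O)[O-])c2)cc1)N[C@H]1CCOC1=O`. The change is 3-nitrophenyl in place of 2,4-dichlorophenyl on a double-bonded chain carbon bound to a double-bonded chain carbon. The shared core stays as it is; only the aryl group on the double-bonded chain carbon is exchanged. Among the measured compounds shown here, no measured pair shows this kind of exchange, so there is no direct guide to how large the step should be.

He expects the step from compound 1 to compound 3 to be small, a 1.2-fold higher number from compound 1 to compound 3 (0.06 log units; within the scatter), with no direction settled beyond the usual scatter. The value of compound 3 in this assay is estimated at 10000 nM, within a range from 3000 nM to 40000 nM.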

Compound 3, half-maximal inhibitory concentration: 41800 nM
The estimate for compound 3 lay 4.2-fold (0.62 log units) below the measured number, outside the stated range (above it).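

In this assay, the exchange of 2,4-dichlorophenyl for 3-nitrophenyl on a double-bonded chain carbon bound to a double-bonded chain carbon gives a 4.9-fold higher number from compound 1 to compound 3 (0.69 log units; beyond the scatter). This shows that the number responds to the aryl group at this place, which the first two compounds could not show, as they differ in more than one place. Compound 3 keeps the shared core and still gives a measured number, 41800 nM, so the exchange weakens inhibition on this read-out without removing it, although the values shown offer no measured property that would account for the step.

The compounds shown leave open whether the step follows from the loss of the two chlorine atoms or from the arrival of the nitro group, and where a plain phenyl, a methoxyphenyl or an aminophenyl would stand at this place. They also leave open whether the same exchange would give a step of similar size on any other core.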